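This account rests on a few compounds, and the source may have more. Where it says the series, first, only, none or still open, it means among the compounds named here.

Measured compounds in an ADME assay on CCRF-CEM cells (Homo sapiens) for cytotoxicity, with a stated time of 3 days; a lower number here means that less compound is tolerated, a higher number that more compound is tolerated:
Compound 1 `Cc1cc(=O)[nH]c(=O)n1C1C=CC(OC(=O)c2ccccc2)C1` gives > 250000 nM, which is a limit of this assay rather than a number.
Compound 2 `Cc1cc(=O)n(C(=O)c2ccccc2)c(=O)n1C1C=CC(OC(=O)c2ccccc2)C1` gives 191000 nM.
Compound 3 `O=C(OC1C=CC(n2ccc(=O)n(C(=O)c3ccccc3)c2=O)C1)c1ccccc1` gives >= 250000 nM, again a limit of this assay.

Only compound 2 has a number. The change hydrogen in place of benzoyl on an aromatic nitrogen gave the step of an at least 1.3-fold higher number from compound 2 to compound 1 (0.11 log units; that floor lies within the scatter). The two cores differ by hydrogen in place of methyl on an aromatic carbon, with the step of an at least 1.3-fold higher number from compound 2 to compound 3 (0.11 log units; that floor lies within the scatter).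

Compound 4 `O=C(OC1C=CC(n2ccc(=O)[nH]c2=O)C1)c1ccccc1` is not yet measured. It differs from compound 3 by hydrogen in place of benzoyl on an aromatic nitrogen. This is the same kind of change as that made from compound 2 to compound 1, but not the same: around the place in compound 2 the ring is also para to a methyl group, which is absent around the place in compound 3. Since the earlier step of an at least 1.3-fold higher number from compound 2 to compound 1 (0.11 log units; that floor lies within the scatter) reached the limit, a comparable step is expected here, a step that the limit leaves unreadable from compound 3 to compound 4, resting on that step alone. Compound 4 is therefore expected to give about 320000 nM, estimated between 200000 nM and 700000 nM, most likely reported only as a limit.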

Compound 4, half-maximal cytotoxic concentration: > 250000 nM
Compound 4: only a limit was reported; the forecaster's own chance of this, stated with the estimate: 85%; the middle value does not contradict the limit.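

In this assay compound 4 gives > 250000 nM, a limit and not a number. The steps to compound 4 from compound 3 and from compound 1 cannot be read. Still open, as far as these compounds go, is where compound 1, compound 3 and compound 4 actually lie relative to one another.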